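The source may report more compounds than this note shows. Statements on the series, on what has been measured and on what is new or still open speak of the compounds shown alone.

Of the compounds shown here, three built on one shared core have been measured. In an assay on cells for inhibition of S-adenosylmethionine decarboxylase proenzyme (Homo sapiens), read by mass spectrometry, at pH 7.2, tested at 180 uM (on this read-out lower numbers stand for less inhibition and higher numbers for more inhibition at the one concentration tested (going by the name of the read-out)), compound 1 `Cc1cc(Nc2cc(Cl)cc(Br)c2)nc(N)n1` gives 33%. Compound 2 `CCOc1cc(Br)cc(Nc2cc(C)nc(N)n2)c1` gives 36% in this assay, and compound 3 `Cc1cc(Nc2cc(Br)cc(Br)c2)nc(N)n1` gives 31%. Compound 1 stands second highest of the three numbers; the gaps around it are small, as a number 3 percentage points higher from compound 1 to compound 2 (within the scatter) and a number 2 percentage points lower from compound 1 to compound 3 (within the scatter) both lie within the scatter, as does a number 5 percentage points lower from compound 2 to compound 3 (within the scatter).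

Compound 4 `Cc1cc(Nc2cc(Cl)cc(-c3ccoc3)c2)nc(N)n1` has not yet been measured. It differs from compound 1 by furan-3-yl in place of bromo on an aromatic carbon. The three measured steps all exchange small groups on that same aromatic carbon, and none of them moved the number beyond the scatter. For the measured compounds named here, no measured step brings a ring into that place, so the effect of furan-3-yl is untested. On this basis, the expected step is no change at the digits printed from compound 1 to compound 4 (within the scatter), with a wide uncertainty. Compound 4 is estimated at 33%, expected to fall between 14% and 54%.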

Compound 4, a percentage reported as inhibition, at one concentration (the size of the read-out at that concentration, not a potency): 30%
Compound 4: the middle estimate sits 3 percentage points above what was measured, within the range that was stated.
By their numbers in this assay, from the lowest: compounds 4, 3, 1 and 2 (each within the scatter of the next).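

Bringing furan-3-yl in place of bromo, the first ring at this aromatic carbon, gives a number 3 percentage points lower from compound 1 to compound 4 (within the scatter) in this assay and adds a hydrogen-bond acceptor. A group of five heavy atoms therefore leaves the number as unresolved from that of compound 1 as the smaller exchanges did. Going by these compounds, whether an amine, a carboxylic acid or a longer chain at this carbon would move the number beyond the scatter remains open. Nothing among the data given accounts for this outcome.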